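The compounds below may be only part of what the source reports. "The series", "measured", "known", "first", "only" and "open" are said of these compounds alone.

In a functional assay on Z-138 cells (Homo sapiens) for inhibition, read by luminescence and CellTiter-Glo, with a stated time of 72 h (a lower number here means a stronger inhibitor, a higher number a weaker inhibitor), compound 1 `C/C=C/C(=O)Nc1cccc(Cn2nc(-c3ccc(Oc4ccccc4)cc3)cc2C(=O)O)c1` gives 24100 nM, the higher of the two plain numbers recorded here. Compound 2 `C/C=C/C(=O)N1CCCC(n2nc(-c3ccc(Oc4ccccc4)cc3)cc2C(=O)OCC)C1`, which carries an ethoxycarbonyl group, gives 19100 nM in this assay, and the gap between the two numbers lies within the usual scatter, so neither can be called the stronger inhibitor. Compound 3 `C=CC(=O)N1CCCC(n2nc(-c3ccc(Oc4ccccc4)cc3)cc2C(=O)O)C1`, which carries a carboxy group, gives only a limit in this assay, > 60000 nM, and that limit is the limit of > 60000 nM in this assay, at which 1 of the 3 values shown sits.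

Compound 4 `C/C=C/C(=O)Nc1cccc(Cn2nc(-c3ccc(Oc4ccccc4)cc3)cc2C(=O)OCC)c1` has not yet been measured. It differs from compound 1 by a single change: ethyl in place of hydrogen on an oxygen next to a carbonyl group. Among the measured compounds shown here, no measured pair here isolates that change. Compound 2, with the ethoxycarbonyl group, gives a plain number, whereas compound 3, with the carboxy group, gives only a limit; but the two also differ in another part of the molecule, so what they show is only a hint, not a clean step.

Taking that hint cautiously, a modest move toward a lower number is expected from compound 1 to compound 4, a 2.2-fold lower number from compound 1 to compound 4 (0.34 log units; beyond the scatter). Compound 4 is therefore estimated at 11000 nM, in a range from 3500 nM to 35000 nM.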

Compound 4, half-maximal inhibitory concentration: 8900 nM
For compound 4 the middle estimate is 1.2-fold (0.09 log units) above the measured one; low and high end bracket the measured number.
By their numbers in this assay, from the lowest: compound 4; then compounds 2 and 1 (each within the scatter of the next). At a limit, above all of these: compound 3.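

In this assay, among the compounds shown here, this is the first clean reading of the change on an oxygen next to a carbonyl group: with the rest of the molecule unchanged, going from hydroxy to ethoxy gives a 2.7-fold lower number from compound 1 to compound 4 (0.43 log units; beyond the scatter). The step is modest, but it shows that on this core the ethoxycarbonyl form is the stronger inhibitor of the pair, so a free carboxy group is not required for inhibition at this level. Compound 3, which also carries a carboxy group but differs from compound 1 elsewhere too, gives only a limit and so remains a hint rather than a second step: the limit of > 60000 nM in this assay, at which 1 of the 4 values shown sits.

As far as these compounds go, whether a methyl or a longer chain on that oxygen, or an amide in place of the ester, would move the number further stays open. It is also open whether the same step holds on the core of compound 2, and the compounds shown do not tell why the ethyl group lowers the number.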